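This account rests on a few compounds, and the source may have more. Where it says the series, first, only, none or still open, it means among the compounds named here.

Of the compounds shown here, two have so far been tested in an assay on membranes from CHO cells for displacement of a labelled ligand from adenosine receptor A1 (Homo sapiens), read by scintillation counting, with a stated time of 60 min, tested at 1 uM; on this read-out higher numbers stand for more inhibition at the one concentration tested (going by the name of the read-out) and lower numbers for less inhibition. Compound 1, `CC(=O)C1=C(C)NC(=O)NC1c1ccsc1`, gives 9%. Compound 2, `CC1=C(C(=O)SC(C)C)C(c2ccoc2)NC(=O)N1`, gives 9%, so compound 2 stands level with compound 1, the two values lying within the scatter. Compound 3, `CC1=C(C(=O)SC(C)C)C(c2ccsc2)NC(=O)N1`, has not been measured yet; it differs from compound 2 by thiophen-3-yl in place of furan-3-yl on a saturated ring carbon. For the measured compounds named here, no step between measured compounds is available to gauge such a change, so no step from compound 2 to compound 3 beyond the scatter is expected in this assay. Compound 3 is expected to give 9%, with a range from 0% to 25%. That corresponds to an estimated step of no change at the digits printed from compound 2 to compound 3 (within the scatter).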

Compound 3, a percentage reported as inhibition, at one concentration (the size of the read-out at that concentration, not a potency): 24%
Beside the measured number, compound 3's estimate is 15 percentage points below it; the measured number falls inside the stated range.
By their numbers in this assay, from the lowest: compounds 1 and 2 (each within the scatter of the next); then compound 3.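

In this assay, thiophen-3-yl in place of furan-3-yl on the saturated ring carbon gives a number 15 percentage points higher from compound 2 to compound 3 (beyond the scatter), the first sign that the read-out responds to the ring at this position. With thiophen-3-yl kept, isopropylsulfanyl in place of methyl on the carbonyl carbon gives a number 15 percentage points higher from compound 1 to compound 3 (beyond the scatter), so the group on the carbonyl carbon matters too. Nothing measured explains either step. Still open, on these data alone, is how a phenyl ring at the saturated ring carbon would read, or a longer chain such as hexylsulfanyl on the carbonyl carbon.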